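Swapping a sulfonamide arm for an acetylpiperidine amide

This account rests on a few compounds, and the source may have more. Where it says the series, first, only, none or still open, it means among the compounds named here.

Compound 1 `COc1ccc(S(=O)(=O)Nc2ccc3oc(-c4ccc(NS(=O)(=O)c5cc(F)ccc5OC)cc4)nc3c2)cc1` gives > 100000 nM in an assay on isolated protein for inhibition of thiosulfate sulfurtransferase (Homo sapiens) (on this read-out lower numbers stand for stronger inhibition and higher numbers for weaker inhibition), which is a limit of the assay and not a number.
Compound 2 `O=S(=O)(Nc1ccc(-c2nc3cc(NS(=O)(=O)c4ccc(Br)cc4)ccc3o2)cc1)c1ccc(Br)cc1` gives > 100000 nM in this assay, again a limit.
Compound 3 `Cc1ccc(S(=O)(=O)Nc2ccc(-c3nc4ccc(NS(=O)(=O)c5ccc(C)cc5)cc4[nH]3)cc2)cc1` gives > 100000 nM in this assay, again a limit.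

For the measured compounds named here, compound 1 thus stands at the limit of > 100000 nM in this assay, at which 3 of the 3 values shown sit; nothing among the three measured compounds shows a real number, so no compound can be ranked against another. Compound 4 `COc1ccc(S(=O)(=O)Nc2ccc3oc(-c4ccc(NC(=O)C5CCN(C(C)=O)CC5)cc4)nc3c2)cc1` differs from compound 1 in one place: a group of 11 heavy atoms (8 carbon, 1 nitrogen, 2 oxygen; one six-membered non-aromatic ring with 1 hetero atom) in place of a group of 12 heavy atoms (7 carbon, 3 oxygen, 1 fluorine, 1 sulfur; one six-membered aromatic ring of carbon only), on a nitrogen on an aromatic ring. Going by the values given here, no step between two measured compounds exists, and with every value a limit, no change beyond the scatter is expected in this assay in either direction. Among the compounds with values here, compound 4 is therefore expected to give about 100000 nM, somewhere between 20000 nM and 500000 nM, so that the expected step of a number no higher from compound 1 to compound 4 (the limit leaves the size open) amounts to no step at all.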

Compound 4, half-maximal inhibitory concentration: > 100000 nM
Compound 4: no number, only a limit; the forecaster's own chance of this, stated with the estimate: 80%; the middle value sits exactly at the limit.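

The step from compound 1 to compound 4 cannot be read: both compounds give only a limit, not a number. The compounds shown leave open whether the (1-acetylpiperidin-4-yl)carbonyl group changes inhibition at all in this assay.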